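The source may hold more compounds than are shown below. What is called first, only, known or untested is meant among the compounds shown, and "the series" means these compounds.

Series notes. Compound 1 `COc1ccc(C2CC(c3ccccc3)=NN2C2=NC(=O)/C(=C3\C(=O)Nc4ccccc43)S2)cc1`, compound 2 `COc1ccc(C2CC(c3ccccc3)=NN2C2=NC(=O)/C(=C3\C(=O)Nc4ccc(Br)cc43)S2)cc1` and compound 3 `COc1ccc(C2CC(c3ccc4ccccc4c3)=NN2C2=NC(=O)/C(=C3\C(=O)Nc4ccccc43)S2)cc1` have been measured; compound 4 `COc1ccc(C2CC(c3ccc4ccccc4c3)=NN2C2=NC(=O)/C(=C3\C(=O)Nc4ccc(Br)cc43)S2)cc1` has not.

In a functional assay on cells (Cancer cell lines, Homo sapiens) for cytotoxicity, read by sulforhodamine B assay, with a stated time of 48 h (on this read-out higher numbers stand for weaker inhibition of growth and lower numbers for stronger inhibition of growth), compound 1 gives 2020 nM, compound 2 gives 200 nM and compound 3 gives 5960 nM, the highest of the three numbers.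

Two structural changes are counted among the measured compounds. Compound 2 differs from compound 1 by bromo in place of hydrogen on an aromatic carbon, and this change gave a 10-fold lower number from compound 1 to compound 2 (1.00 log units; beyond the scatter). Compound 3 differs from compound 1 in its core by naphthalen-2-yl in place of phenyl on a carbon with a double bond to nitrogen, and this change gave a 3.0-fold higher number from compound 1 to compound 3 (0.47 log units; beyond the scatter).

Compound 4 differs from compound 3 by bromo in place of hydrogen on an aromatic carbon, the same change, at the same place, as that from compound 1 to compound 2, now made on the core of compound 3. For the measured compounds named here, only one observation of this change exists, so the expectation rests on a single step.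

The step from compound 3 to compound 4 is expected to be a 7.5-fold lower number from compound 3 to compound 4 (0.87 log units; beyond the scatter), resting on the step seen as a 10-fold lower number from compound 1 to compound 2 (1.00 log units; beyond the scatter) and allowing for the change to carry less well on the core of compound 3. Compound 4 is therefore estimated at 800 nM, between 250 nM and 2500 nM, pending measurement.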

Compound 4, concentration for 50% growth inhibition: 61 nM
The estimate for compound 4 lay 13-fold (1.12 log units) above the measured number; the whole stated range lies above it.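

In this assay, bromo in place of hydrogen on the aromatic carbon lowers the number on both cores, but the size of the step does not carry over, with a 98-fold lower number from compound 3 to compound 4 (1.99 log units; beyond the scatter) set against a smaller step on the core of compound 1: the same change on two cores in this assay, a 10-fold lower number (1.00 log units; beyond the scatter) from compound 1 to compound 2 and a 98-fold lower number (1.99 log units; beyond the scatter) from compound 3 to compound 4, 9.7-fold (0.99 log units) apart, beyond the scatter of two such steps Naphthalen-2-yl in place of phenyl does not even keep its direction, giving a 3.3-fold lower number from compound 2 to compound 4 (0.52 log units; beyond the scatter) on the bromo core, whereas it raises the number on the core without bromo: the same change on two cores in this assay, a 3.0-fold higher number (0.47 log units; beyond the scatter) from compound 1 to compound 3 and a 3.3-fold lower number (0.52 log units; beyond the scatter) from compound 2 to compound 4, 9.7-fold (0.99 log units) apart, beyond the scatter of two such steps The two changes are therefore not additive across these four compounds, but this is a single set of four that shows one gap seen from two sides, so it gives neither a reason for the gap nor a rule for other cores.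

From the compounds shown here alone, it remains open whether chloro, nitro or an amine on the same aromatic carbon would behave as bromo does on either core. Going by these compounds, it is equally open whether naphthalen-1-yl or a pyridine ring in place of naphthalen-2-yl would show the same dependence on bromo.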